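Swapping a thiophene for a methylpyrazole on a weak antiproliferative scaffold

The source may report more compounds than this note shows. Statements on the series, on what has been measured and on what is new or still open speak of the compounds shown alone.

Compound 1 `CCN(c1ccc(C#N)c(Cl)c1)c1cc(-c2cccs2)ccc1C` was tested in a functional assay on CWR22R cells (Homo sapiens) for antiproliferative activity, read by CCK-8 assay, with a stated time of 6 days (a lower number here means a stronger inhibitor, a higher number a weaker inhibitor), where compound 1 gives 22000 nM. Among the compounds with values here, the only companion with a number is compound 2 `CCN(c1ccc(C#N)c(C(F)(F)F)c1)c1cc(-n2ccnc2)ccc1C`, which in this assay gives 16300 nM; the two values lie within the usual scatter of each other, so neither compound can be called the weaker inhibitor, and both are feeble. Compound 3 `CCN(c1ccc(C#N)c(Cl)c1)c1cc(-c2ccnn2C)ccc1C` differs from compound 1 by 1-methyl-1H-pyrazol-5-yl in place of thiophen-2-yl on an aromatic carbon. Within the data shown here, no step between two measured compounds mirrors this change, so there is no direct guide to its size. Since compound 2, which also carries a nitrogen-containing five-membered ring at the same place, gives 16300 nM, the change is expected to leave the number near where compound 1 stands, with a step of a 1.5-fold lower number from compound 1 to compound 3 (0.17 log units; within the scatter) that is estimated to stay within the scatter. Compound 3 is therefore expected to give about 15000 nM, in a range from 5000 nM to 45000 nM.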

Compound 3, half-maximal inhibitory concentration: 4330 nM
The estimate for compound 3 lay 3.5-fold (0.54 log units) above the measured number, and the stated range ends above it.
By their numbers in this assay, from the lowest: compound 3; then compounds 2 and 1 (each within the scatter of the next).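

The change gives a 5.1-fold lower number from compound 1 to compound 3 (0.71 log units; beyond the scatter) in this assay and is the only step shown at this place, an aromatic carbon para to a methyl group. Thiophen-2-yl and 1-methyl-1H-pyrazol-5-yl are both five-membered aromatic rings, yet exchanging one for the other, with the rest of compound 1 unchanged, moves the number beyond the scatter, so the identity of this ring matters and not merely its presence. No measurement at hand says why the number moved.

Compound 2 differs from compound 3 in more than one place, so it cannot separate the roles of the ring nitrogens and the methyl group on the new ring. Also open, from the compounds shown here alone, is what an unsubstituted pyrazole, a phenyl ring or an amine would give at this place.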